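Removing the trifluorobenzyl group from a nucleoside analogue

The source may hold more compounds than are shown below. What is called first, only, known or untested is meant among the compounds shown, and "the series" means these compounds.

Among the compounds with values here, compound 3 `Nc1ncnc2c1nc(NCc1ccc(Cl)c(Cl)c1)n2[C@@H]1O[C@H](COCc2cc(F)c(F)c(F)c2)[C@@H](O)[C@H]1O` is the only one of three measured compounds that gives an actual number in a functional assay on HCT-116 cells (Homo sapiens) for cytotoxicity, read by sulforhodamine B assay; a lower number here means a stronger inhibitor of growth, a higher number a weaker inhibitor of growth: compound 3 gives 13000 nM. Compound 1 `COC[C@H]1O[C@@H](n2c(NCc3ccc(Cl)c(Cl)c3)nc3c(N)ncnc32)[C@H](O)[C@@H]1O` reaches only a limit of this assay, > 80000 nM. Compound 2 `Nc1ncnc2c1nc(NCc1ccc(Cl)c(Cl)c1)n2[C@@H]1O[C@H](COCc2ccccc2)[C@@H](O)[C@H]1O` likewise reaches only a limit, > 80000 nM. Two of the three values therefore sit at the same ceiling (the limit of > 80000 nM in this assay, at which 2 of the 3 values shown sit). Compound 4 `Nc1ncnc2c1nc(NCc1ccc(Cl)c(Cl)c1)n2[C@@H]1O[C@H](CO)[C@@H](O)[C@H]1O` is not yet measured; it differs from compound 3 in one place (hydrogen in place of 3,4,5-trifluorobenzyl on an oxygen on a saturated carbon).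

The measured steps bear on this directly. The step of an at least 6.1-fold lower number from compound 1 to compound 3 (0.78 log units; beyond the scatter) and the step of an at least 6.1-fold lower number from compound 2 to compound 3 (0.78 log units; beyond the scatter) both show that arriving at the 3,4,5-trifluorophenyl group brought the number down out of the limit, while the step that the two limits leave unreadable from compound 1 to compound 2 cannot be sized. Stripping the group away entirely is expected to undo that gain, so compound 4 is expected to move by a 7.7-fold higher number from compound 3 to compound 4 (0.89 log units; beyond the scatter), most likely back to a limit. Compound 4 is therefore estimated at 100000 nM, with a range from 30000 nM to 300000 nM.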

Compound 4, concentration for 50% growth inhibition: 26000 nM
Compound 4: middle estimate off by 3.8-fold (0.59 log units), on the high side; measured number outside the range, below it.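

Replacing the 3,4,5-trifluorobenzyl group with hydrogen on this oxygen gives a 2.0-fold higher number from compound 3 to compound 4 (0.30 log units; within the scatter) in this assay, so the trifluorinated group is not needed for a measurable number here. The compounds with simpler groups on the same oxygen are the ones that stand apart, with an at least 3.0-fold lower number from compound 1 to compound 4 (0.48 log units; beyond the scatter) for hydrogen in place of methyl and an at least 3.0-fold lower number from compound 2 to compound 4 (0.48 log units; beyond the scatter) for hydrogen in place of benzyl. Among these four compounds, the result therefore does not follow the size of the group, as hydrogen and 3,4,5-trifluorobenzyl both give a number while methyl and benzyl do not: the limit of > 80000 nM in this assay, at which 2 of the 4 values shown sit.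

On these data alone, it remains open where an ethyl group or a benzyl group carrying a single fluorine would fall on this oxygen. As far as these compounds go, it is also open what an amine in place of this oxygen would do.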